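From carboxy to ethoxycarbonyl at the assay limit

The compounds below may be only part of what the source reports. "The series", "measured", "known", "first", "only" and "open" are said of these compounds alone.

Measured compounds in a functional assay on MCF7 cells (Homo sapiens) for cytotoxicity, read by MTT assay (a lower number here means a stronger inhibitor, a higher number a weaker inhibitor), each value a limit:
- compound 1 `COc1ccc(-c2oc3c(CC=C(C)C)c(OC/C=C/C(=O)O)cc(O)c3c(=O)c2O)cc1` gives > 100000 nM as a limit
- compound 2 `COc1ccc(-c2oc3c(CC=C(C)C)c(OCC(=O)O)cc(O)c3c(=O)c2O)cc1` gives > 100000 nM as a limit

Compound 2 stands at > 100000 nM as a limit of the assay and not as a number. Among the compounds with values here, the whole series so far shares one reading: the limit of > 100000 nM in this assay, at which 2 of the 2 values shown sit. Within the data shown here, the only measured step is a step that the two limits leave unreadable from compound 1 to compound 2, so it offers no size to carry forward.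

Compound 3 `CCOC(=O)COc1cc(O)c2c(=O)c(O)c(-c3ccc(OC)cc3)oc2c1CC=C(C)C` keeps the core of compound 2 and differs in one place: ethyl in place of hydrogen on an oxygen next to a carbonyl group. In words, this is ethyl in place of hydrogen on an oxygen next to a carbonyl group, or carboxy to ethoxycarbonyl. Among the measured compounds shown here, no measured compound carries this change, so the size of the step has no measured precedent. With compound 2 at > 100000 nM as a limit, a readable value for compound 3 could lie only on the stronger side. A modest step in that direction is therefore expected in this assay, though another result at the limit remains quite possible. The estimated change is an at least 2.5-fold lower number from compound 2 to compound 3 (0.39 log units; beyond the scatter). For compound 3 the estimated value is 40000 nM, with an expected range from 10000 nM to 100000 nM.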

Compound 3, half-maximal inhibitory concentration: 27900 nM
Beside the measured number, compound 3's estimate is 1.4-fold (0.16 log units) above it; the range from low to high includes it.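

In this assay, compound 3 is the only compound shown with a readable number, 27900 nM, so the change from carboxy to ethoxycarbonyl gives the series a readable value. Ethyl in place of hydrogen on an oxygen next to a carbonyl group gives an at least 3.5-fold lower number from compound 2 to compound 3 (0.55 log units; beyond the scatter), and ethoxycarbonyl in place of 2-carboxyethenyl gives an at least 3.5-fold lower number from compound 1 to compound 3 (0.55 log units; beyond the scatter); both steps start from a limit, so each gives only a minimum size and the true size of the change remains unknown. The step from compound 1 to compound 2 cannot be read, and the series still rests mostly on limits: the limit of > 100000 nM in this assay, at which 2 of the 3 values shown sit.

From the compounds shown here alone, whether a readable value belongs to ethoxycarbonyl alone or extends to methoxycarbonyl, to a longer ester such as butoxycarbonyl, or to a primary amide stays open. Also open, going by these compounds, is how the ethyl ester of the 2-carboxyethenyl chain of compound 1 would read, which would show whether the longer unsaturated chain shifts the number once the acid hydrogen is replaced by ethyl.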